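Methoxy for hydroxy on the pendant aryl: cytotoxicity notes

The compounds below may be only part of what the source reports. "The series", "measured", "known", "first", "only" and "open" are said of these compounds alone.

The three measured compounds share one core and differ only in the aryl group on the saturated ring carbon. Compound 1 `N#CC1=C(N)N(c2ccc(S(N)(=O)=O)cc2)C2=C(CCCC2)C1c1ccccc1O` carries a 2-hydroxyphenyl group; in a functional assay on Ehrlich cells (Mus musculus) for cytotoxicity, read by trypan blue exclusion, with a stated time of 2 h, tested at 10 ug/mL (on this read-out higher numbers stand for a stronger effect at the one concentration tested and lower numbers for a weaker effect), compound 1 gives 10%. Compound 2 `COc1ccccc1C1C(C#N)=C(N)N(c2ccc(S(N)(=O)=O)cc2)C2=C1CCCC2` differs from compound 1 by methyl in place of hydrogen on an oxygen on an aromatic ring, and in this assay compound 2 gives 30%; the step is a number 20 percentage points higher from compound 1 to compound 2 (beyond the scatter). Compound 3 `N#CC1=C(N)N(c2ccc(S(N)(=O)=O)cc2)C2=C(CCCC2)C1c1c(O)ccc2ccccc12` differs from compound 1 by 2-hydroxynaphthalen-1-yl in place of 2-hydroxyphenyl on a saturated ring carbon; in this assay compound 3 gives 10%, and the step is no change at the digits printed from compound 1 to compound 3 (within the scatter). Between compound 2 and compound 3 the step is a number 20 percentage points lower from compound 2 to compound 3 (beyond the scatter), so compound 3 sits level with compound 1 at the digits given and apart from compound 2.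

Compound 4 `COc1ccc2ccccc2c1C1C(C#N)=C(N)N(c2ccc(S(N)(=O)=O)cc2)C2=C1CCCC2` is not yet measured. It differs from compound 3 by methyl in place of hydrogen on an oxygen on an aromatic ring. This is the same change as that from compound 1 to compound 2: the place is described in the same words for both, an oxygen on an aromatic ring whose other neighbours are aromatic carbon. The two cores differ by 2-hydroxynaphthalen-1-yl in place of 2-hydroxyphenyl on a saturated ring carbon, which on its own left the read-out unchanged.

The earlier instance of this change moved the read-out by a number 20 percentage points higher from compound 1 to compound 2 (beyond the scatter). Within the data shown here, with only one precedent, the expected step in this assay from compound 3 to compound 4 is taken as a number 20 percentage points higher from compound 3 to compound 4 (beyond the scatter), resting on that single prior step. Compound 4 is therefore estimated at 30% in this assay, with an expected range from 15% to 50%; the range is wide because the basis is one step of a number 20 percentage points higher from compound 1 to compound 2 (beyond the scatter) on a different aryl group.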

Compound 4, a percentage reported as activity, at one concentration (the size of the read-out at that concentration, not a potency): 5%
Compound 4: the middle estimate sits 25 percentage points above what was measured; the measured number lies below the stated range.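

On the 2-hydroxynaphthalen-1-yl aryl group, in this assay the change from hydroxy to methoxy gives a number 5 percentage points lower from compound 3 to compound 4 (within the scatter) and so does not repeat the rise seen on the 2-hydroxyphenyl aryl group. This shows that, for these two pairs, the step measured on one aryl group cannot be carried over to the other; it does not show why the two differ, and with one pair for each aryl group at a single concentration it gives no rule for any other aryl group in the series. Set side by side, the two instances of the change disagree: the same change on two cores in this assay, a number 20 percentage points higher (beyond the scatter) from compound 1 to compound 2 and a number 5 percentage points lower (within the scatter) from compound 3 to compound 4, 25 percentage points apart, beyond the scatter of two such steps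

The compounds shown leave open how the same change behaves on an aryl group that also carries a further substituent, such as an amine or a carboxylic acid, and whether a longer chain on the oxygen, such as ethyl or propyl, follows methyl on either aryl group. Also open, on these data alone, is whether the disagreement between the two pairs persists at concentrations other than the one tested, where a full concentration-response comparison would be needed to separate the compounds.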